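The source may report more compounds than this note shows. Statements on the series, on what has been measured and on what is new or still open speak of the compounds shown alone.

Of the compounds shown here, three of a shared core have been measured so far, and compound 1 `Cc1ccc(NC2=CC(=O)c3nc4n(c3C2=O)[C@H]2OC[C@@H](O)[C@H]2OC4)cc1` serves as the starting point. In a functional assay on MGC-803 cells (Homo sapiens) for inhibition, read by sulforhodamine B assay (on this read-out lower numbers stand for stronger inhibition and higher numbers for weaker inhibition), compound 1 gives 1420 nM. Compound 3 `Cc1ccc(NC2=CC(=O)c3c(nc4n3[C@H]3OC[C@@H](O)[C@H]3OC4)C2=O)cc1` gives 1550 nM in this assay, and compound 2 `COc1ccc(NC2=CC(=O)c3c(nc4n3[C@H]3OC[C@@H](O)[C@H]3OC4)C2=O)cc1` gives 2150 nM. Compound 1 thus has the lowest number of the three, but its distance to compound 3 and to compound 2 lies within the usual scatter of this measurement, so the three cannot be ranked with confidence.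

For the measured compounds named here, the one step between measured compounds that differ in a single place is a 1.4-fold lower number from compound 2 to compound 3 (0.14 log units; within the scatter), a swap of one small group for another on the aromatic ring.

Compound 4 `O=C1C=C(N2CCCCC2)C(=O)c2c1nc1n2[C@H]2OC[C@@H](O)[C@H]2OC1` differs from compound 1 by piperidin-1-yl in place of (4-methylphenyl)amino on a double-bonded ring carbon. Going by the values given here, no measured step touches this kind of change: the only step available concerns a group on the aromatic ring, whereas here the whole (4-methylphenyl)amino group leaves and piperidin-1-yl enters. The expectation for compound 4 is therefore uncertain, and a change of either direction beyond the scatter remains possible. Compound 4 is estimated to give 2500 nM, with a range from 700 nM to 9000 nM. This estimate corresponds to an expected step of a 1.8-fold higher number from compound 1 to compound 4 (0.25 log units; within the scatter).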

Compound 4, half-maximal inhibitory concentration: > 8000 nM
Compound 4: no number, only a limit (the forecaster's own chance of this, stated with the estimate: 10%); at least 3.2-fold (0.50 log units) between middle value and limit.
By their numbers in this assay, from the lowest: compounds 1, 3 and 2 (each within the scatter of the next). At a limit, above all of these: compound 4.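

Setting piperidin-1-yl in place of (4-methylphenyl)amino on the double-bonded ring carbon gives an at least 5.6-fold higher number from compound 1 to compound 4 (0.75 log units; beyond the scatter). This shows that in this assay the group at this position can move the read-out beyond the scatter, which the earlier step, a small swap on the aromatic ring that stayed within the scatter, could not show. For compound 4 there is only a limit and not a number: the limit of > 8000 nM in this assay, at which 1 of the 4 values shown sits.

For the compounds shown here, the change also alters several things at once: an aromatic ring of carbon only leaves, a non-aromatic ring with one hetero atom enters, and the hydrogen-bond donor of the leaving group has no counterpart in the entering one. The compounds shown therefore leave open which of these differences carries the step. A cyclohexylamino group, which pairs a non-aromatic ring with an amino hydrogen, and a methyl(phenyl)amino group, which keeps the aromatic ring but has no amino hydrogen, would each separate these two differences at this same position.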